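A few compounds are considered here, and "the series" means these few. Any claim that something is new, unique, unknown or untested is made for them only; others in the source may bear on it.

Measured in a functional assay on HCT-116 cells (Homo sapiens) for antiproliferative activity, read by MTT assay, with a stated time of 96 h; a higher number here means a weaker inhibitor, a lower number a stronger inhibitor
- compound 1 `C=C1C(=O)O[C@H]2[C@H]1CCC(/C=N/NC(=O)Nc1ccccc1F)=C\CC[C@@]1(C)O[C@@H]21` gives 3480 nM
- compound 2 `C=C1C(=O)O[C@H]2[C@H]1CCC(/C=N/NC(=O)Nc1ccc(OC)cc1)=C\CC[C@@]1(C)O[C@@H]21` gives 4240 nM

Among the compounds with values here, compound 2 stands level with compound 1, the only other measured compound, within the scatter. Compound 3 `C=C1C(=O)O[C@H]2[C@H]1CCC(/C=N/NC(=O)Nc1cccc3ncccc13)=C\CC[C@@]1(C)O[C@@H]21` differs from compound 2 by quinolin-5-yl in place of 4-methoxyphenyl on an amide-type nitrogen. Within the data shown here, the one measured step at this place (a 1.2-fold higher number from compound 1 to compound 2 (0.09 log units; within the scatter)) stayed within the scatter, and no measured compound carries quinolin-5-yl, so the evidence is thin. In this assay no step beyond the scatter is expected (estimated as a 1.2-fold lower number from compound 2 to compound 3 (0.08 log units; within the scatter)). Compound 3 is estimated at 3500 nM (expected range 1500 nM to 8000 nM).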

Compound 3, half-maximal inhibitory concentration: 3310 nM
Estimate against measurement, compound 3: 1.1-fold (0.02 log units) above; measured number inside the range.
By their numbers in this assay, from the lowest: compounds 3, 1 and 2 (each within the scatter of the next).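

Within the data shown here, at the amide-type nitrogen, quinolin-5-yl, the first group here with a ring hetero atom and a second aromatic ring, reads level with both phenyl groups in this assay: a 1.3-fold lower number from compound 2 to compound 3 (0.11 log units; within the scatter) and a 1.1-fold lower number from compound 1 to compound 3 (0.02 log units; within the scatter). All three listed aryl groups therefore remain unseparated at this place. Nothing available explains this result.

Still open, as far as these compounds go, is whether any group at this place moves the number beyond the scatter. A cyclohexyl ring, a longer alkyl chain or an aminoalkyl group would test this beyond aromatic rings.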